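The source may report more compounds than this note shows. Statements on the series, on what has been measured and on what is new or still open speak of the compounds shown alone.

Of the compounds shown here, three have been measured in a functional assay on the whole organism with Rattus norvegicus as the target (a lower number here means that less compound is needed, a higher number that more compound is needed for the effect), and a fourth awaits measurement. Compound 1 `CCN(CCNC(=O)c1cc(Cl)c(N)cc1OC)Cc1ccc(Cl)cc1` gives 0.24 mg/kg in this assay. Compound 2 `COc1cc(N)c(Cl)cc1C(=O)NCCN(Cc1ccc(Cl)cc1)C(C)C` is built the same way except for one change, (methyl in place of hydrogen on a saturated chain carbon bound to an amine nitrogen and a saturated chain carbon), and in this assay compound 2 gives 3 mg/kg. That single added methyl made a large step, a 13-fold higher number from compound 1 to compound 2 (1.10 log units; beyond the scatter), so more of compound 2 was needed for the same effect.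

Compound 3 `CCNc1cc(OC)c(C(=O)NC2CCN(Cc3ccccc3)C2)cc1Cl` rests on a different core; the difference between the two cores is not broken down here. In this assay compound 3 gives 0.1 mg/kg, the lowest of the three numbers.

Compound 4 `CCCNc1cc(OC)c(C(=O)NC2CCN(Cc3ccccc3)C2)cc1Cl` differs from compound 3 by methyl in place of hydrogen on a saturated chain carbon, two bonds along the chain from a nitrogen on an aromatic ring. Among the compounds with values here, this is the same kind of change as the one from compound 1 to compound 2, a methyl in place of a hydrogen on a saturated chain carbon, but not the same: in the earlier case the carbon was bound to an amine nitrogen and a saturated chain carbon, whereas here it sits two bonds along the chain from a nitrogen on an aromatic ring. The earlier step was made at a different place, so the large step of a 13-fold higher number from compound 1 to compound 2 (1.10 log units; beyond the scatter) gives only loose guidance for compound 4. For compound 4 a smaller step is expected, a 2.0-fold higher number from compound 3 to compound 4 (0.30 log units; within the scatter), leaning toward a somewhat higher number. Compound 4 is estimated at 0.2 mg/kg in this assay, most likely between 0.05 mg/kg and 0.7 mg/kg.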

Compound 4, dose for half-maximal effect: 17 mg/kg
Compound 4: middle estimate off by 85-fold (1.93 log units), on the low side; measured number above the stated range.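

Turning the ethylamino group into propylamino gives a 170-fold higher number from compound 3 to compound 4 (2.23 log units; beyond the scatter) in this assay, so far more of compound 4 is needed for the same effect. In both pairs shown, one added methyl raises the number beyond the scatter, but the size of that rise does not carry over from one core to the other: the same change on two cores in this assay, a 13-fold higher number (1.10 log units; beyond the scatter) from compound 1 to compound 2 and a 170-fold higher number (2.23 log units; beyond the scatter) from compound 3 to compound 4, 14-fold (1.13 log units) apart, beyond the scatter of two such steps This does not show what sets the two steps apart: the methyls differ in both core and place, and two pairs alone can neither separate those two differences nor give a rule for the whole series.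

Still open, going by these compounds, is how the number would move on the core of compound 3 with a longer chain such as butylamino, or with a shorter group such as methylamino or a plain amino group, which would show whether the sharp rise continues or belongs to this one step. Also open, on these data alone, is whether a methyl added at the same place on the side chain of compound 1 and on that of compound 3 would give steps of similar size, which is the comparison needed to tell the effect of the core from that of the place.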